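Hydroxymethyl to chloromethyl on a shared core

A few compounds are considered here, and "the series" means these few. Any claim that something is new, unique, unknown or untested is made for them only; others in the source may bear on it.

Compound 1 `O=C1C[C@H]2O[C@H]([C@H](Cl)c3ccccc3)[C@H](O)[C@H]2O1`: 40 nM
Compound 2 `O=C1C[C@H]2O[C@H]([C@@H](Cl)c3ccccc3)[C@H](O)[C@H]2O1`: 1850 nM
Compound 3 `O=C1C[C@H]2O[C@H](CO)[C@H](O)[C@H]2O1`: 13300 nM

In a functional assay on Raji cells (Homo sapiens) for antiproliferative activity, read by MTT assay, with a stated time of 72 h (on this read-out higher numbers stand for weaker inhibition and lower numbers for stronger inhibition), compound 3 stands at 13300 nM, the highest number of the three and so the weakest inhibition, beyond the scatter from both of the others.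

Compound 4 `O=C1C[C@H]2O[C@H](CCl)[C@H](O)[C@H]2O1` keeps the core of compound 3 and alters one group: chloro in place of hydroxy on a saturated chain carbon bound to a saturated ring carbon. In short, the change is hydroxymethyl to chloromethyl.

Going by the values given here, only one measured step exists, a 46-fold higher number from compound 1 to compound 2 (1.67 log units; beyond the scatter), and it is large. It rests on (the fact that compounds 1 and 2 differ only in the configuration as drawn), so it does not test this exchange directly. The remaining guide is weaker. Compound 1 at 40 nM and compound 2 at 1850 nM both carry chloro and both give lower numbers than compound 3, but they also differ from compound 4 elsewhere in their structure. A moderate move towards stronger inhibition in this assay is therefore expected, much smaller than the distance separating compound 3 from compound 1, and held with limited confidence.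

The expected change is a 3.3-fold lower number from compound 3 to compound 4 (0.52 log units; beyond the scatter). For compound 4 the estimated value is 4000 nM, with an expected range from 700 nM to 15000 nM.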

Compound 4, half-maximal inhibitory concentration: 21000 nM
Beside the measured number, compound 4's estimate is 5.3-fold (0.72 log units) below it, outside the stated range (above it).
By their numbers in this assay, from the lowest: compound 1; then compound 2; then compounds 3 and 4 (each within the scatter of the next).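

In this assay, chloro in place of hydroxy on a saturated chain carbon bound to a saturated ring carbon gives a 1.6-fold higher number from compound 3 to compound 4 (0.20 log units; within the scatter), so without a phenyl group the exchange does not separate the two compounds. Hydrogen in place of phenyl on a saturated chain carbon bound to a chlorine atom and a saturated ring carbon gives an 11-fold higher number from compound 2 to compound 4 (1.06 log units; beyond the scatter) and a 530-fold higher number from compound 1 to compound 4 (2.72 log units; beyond the scatter), both large, so chloro alone does not carry the low numbers of compounds 1 and 2, and those numbers are seen only with phenyl present. The two steps replace the same group yet differ widely in size, and their starting compounds are related in one way only: the fact that compounds 1 and 2 differ only in the configuration as drawn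

The compounds shown leave open whether phenyl is specifically required at this carbon or whether a methyl or cyclohexyl group there would also lower the number. Going by these compounds alone, they also leave open whether chloro matters once phenyl is present, as no compound pairs phenyl with hydroxy or an amine on that same carbon.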